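Moving the chloroacetamide arm around its phenyl ring

The source may report more compounds than this note shows. Statements on the series, on what has been measured and on what is new or still open speak of the compounds shown alone.

Compound 1 `CCOC(=O)c1cc(-c2ccc(Oc3ccccc3)cc2)nn1Cc1cccc(NC(=O)CCl)c1` gives 400 nM in a functional assay on JeKo-1 cells (Homo sapiens) for inhibition, read by luminescence and CellTiter-Glo, with a stated time of 72 h (a lower number here means a stronger inhibitor, a higher number a weaker inhibitor), and compound 2 `O=C(CCl)Nc1cccc(Cn2nc(-c3ccc(Oc4ccccc4)cc3)cc2CO)c1` gives 400 nM; together they stand at the lowest numbers of the three measured, level with each other within the scatter. Compound 3 `O=C(CCl)Nc1cccc(Cn2nc(-c3ccc(Oc4ccccc4)cc3)cc2C(=O)O)c1` gives 6300 nM, the highest number. The measured steps are no change at the digits printed from compound 1 to compound 2 (within the scatter), a 16-fold higher number from compound 1 to compound 3 (1.20 log units; beyond the scatter) and a 16-fold higher number from compound 2 to compound 3 (1.20 log units; beyond the scatter); all three concern the group on the aromatic carbon of the shared core and leave the chloroacetamide-bearing phenyl untouched.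

Compound 4 `CCOC(=O)c1cc(-c2ccc(Oc3ccccc3)cc2)nn1Cc1ccc(NC(=O)CCl)cc1` differs from compound 1 only in that phenyl: 4-(((chloromethyl)carbonyl)amino)phenyl in place of 3-(((chloromethyl)carbonyl)amino)phenyl on a saturated chain carbon bound to an aromatic nitrogen. Among the compounds with values here, no measured step touches this part of the molecule, so the size and direction of the change cannot be read from the series; only that the reactive chloroacetamide is kept. The step from compound 1 to compound 4 is therefore expected to be a 1.8-fold higher number from compound 1 to compound 4 (0.24 log units; within the scatter), with wide uncertainty in either direction. For compound 4 the estimated value is 700 nM, expected within 200 nM to 3000 nM.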

Compound 4, half-maximal inhibitory concentration: 400 nM
Beside the measured number, compound 4's estimate is 1.8-fold (0.24 log units) above it; the measured number falls inside the stated range.
By their numbers in this assay, from the lowest: compounds 1, 2 and 4 (each within the scatter of the next); then compound 3.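

Swapping 3-(((chloromethyl)carbonyl)amino)phenyl for 4-(((chloromethyl)carbonyl)amino)phenyl on a saturated chain carbon bound to an aromatic nitrogen gives no change at the digits printed from compound 1 to compound 4 (within the scatter) in this assay. Within the data shown here, the earlier compounds all carried the 3-substituted phenyl, so this is the first reading at this position, and with the ethoxycarbonyl group held, both attachment patterns of the chloroacetamide stand level. No supporting data bear on why the two compounds read alike.

On these data alone, it remains open whether the 4-substituted phenyl stays level when hydroxymethyl or carboxy replaces ethoxycarbonyl on the shared core. As far as these compounds go, the effect of an acrylamide in place of the chloroacetamide, or of a longer chain in place of the saturated chain carbon, also remains open.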